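This account rests on a few compounds, and the source may have more. Where it says the series, first, only, none or still open, it means among the compounds named here.

Compound 1 `COc1ccccc1-c1nnc(-c2ccc(C(=O)N/N=C/c3c(O)cc(O)cc3O)cc2)o1` gives 12400 nM.
Compound 2 `COc1ccc(/C=N/NC(=O)c2ccc(-c3nnc(-c4ccccc4OC)o3)cc2)c(O)c1` gives 308000 nM.
Compound 3 `COc1ccccc1-c1nnc(-c2ccc(C(=O)N/N=C/c3cccnc3)cc2)o1` gives 167000 nM.

These three compounds share one core and differ only in the aromatic ring attached to the carbon with a double bond to nitrogen. In an ADME assay on THP-1 cells (Homo sapiens) for cytotoxicity (a higher number here means a weaker inhibitor, a lower number a stronger inhibitor), compound 1 stands lowest of the three numbers: its step to the nearest neighbour is a 13-fold higher number from compound 1 to compound 3 (1.13 log units; beyond the scatter) and its step to the furthest is a 25-fold higher number from compound 1 to compound 2 (1.40 log units; beyond the scatter), both beyond the scatter, so compound 1 is the strongest inhibitor among them.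

Compound 4 `COc1ccccc1-c1nnc(-c2ccc(C(=O)N/N=C/c3ccccc3O)cc2)o1` has not yet been measured. It differs from compound 1 in one place: 2-hydroxyphenyl in place of 2,4,6-trihydroxyphenyl on a carbon with a double bond to nitrogen. Both measured steps away from compound 1 replaced the same 2,4,6-trihydroxyphenyl with a different ring, and both gave large rises in the number. The two replacements ended close together, since the step between them is a 1.8-fold lower number from compound 2 to compound 3 (0.27 log units; within the scatter), within the scatter. The change to compound 4 again removes the 2,4,6-trihydroxyphenyl, keeping a single hydroxyl, so a large rise in this assay is expected, towards a weaker inhibitor.

Compound 4 is therefore estimated at about 150000 nM, with a range from 40000 nM to 500000 nM. The expected step is a 12-fold higher number from compound 1 to compound 4 (1.08 log units; beyond the scatter).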

Compound 4, half-maximal inhibitory concentration: 207000 nM
The estimate for compound 4 lay 1.4-fold (0.14 log units) below the measured number; the measured number falls inside the stated range.
By their numbers in this assay, from the lowest: compound 1; then compounds 3, 4 and 2 (each within the scatter of the next).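

In this assay, a ring that still carries a hydroxyl does not keep the low number: 2-hydroxyphenyl in place of 2,4,6-trihydroxyphenyl gives a 17-fold higher number from compound 1 to compound 4 (1.22 log units; beyond the scatter), a large step towards a weaker inhibitor, and compound 1 remains the strongest inhibitor of the four. The new compound does not separate from the other replacements, with a 1.2-fold higher number from compound 3 to compound 4 (0.09 log units; within the scatter) and a 1.5-fold lower number from compound 2 to compound 4 (0.17 log units; within the scatter), both within the scatter, so the 2-hydroxyphenyl, pyridin-3-yl and 2-hydroxy-4-methoxyphenyl rings cannot be told apart here, and exchanging methoxy for hydrogen on an aromatic carbon has no readable effect. Among these four compounds, only the 2,4,6-trihydroxyphenyl ring stands apart, and nothing in the data shown explains why.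

The compounds shown leave open whether the low number depends on how many hydroxyl groups the ring carries or on where they sit, a question that a ring such as 2,4-dihydroxyphenyl could begin to address. They also leave open whether hydroxyl groups are needed at all, or whether an amine or a carboxylic acid on the ring would give a similar number.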